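A few compounds are considered here, and "the series" means these few. Any claim that something is new, unique, unknown or untested is made for them only; others in the source may bear on it.

Compound 1, whose structure is `CC1(C)[C@H]2CC[C@]1(C)N(Cc1cn(-c3ccc(C#N)cc3)nn1)C(=O)C2`, is the starting point of this step. In a functional assay on A549 cells (Homo sapiens) for inhibition, read by MTT assay, with a stated time of 24 h (on this read-out higher numbers stand for weaker inhibition and lower numbers for stronger inhibition), compound 1 gives 140 nM, which places it second highest of the three numbers measured. Compound 2, of structure `CC1(C)[C@H]2CC[C@]1(C)N(Cc1cn(-c3ccccc3C#N)nn1)C(=O)C2`, gives 100 nM in this assay, and compound 3, of structure `CC1(C)[C@H]2CC[C@]1(C)N(Cc1cn(-c3ccc(F)cc3)nn1)C(=O)C2`, gives 230 nM. The step of a 1.4-fold lower number from compound 1 to compound 2 (0.15 log units; within the scatter) and the step of a 1.6-fold higher number from compound 1 to compound 3 (0.22 log units; within the scatter) both fall within the scatter, while the step of a 2.3-fold higher number from compound 2 to compound 3 (0.36 log units; beyond the scatter) is modest but beyond it.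

Compound 4, of structure `CC1(C)[C@H]2CC[C@]1(C)N(Cc1cn(-c3cccc(Cl)c3)nn1)C(=O)C2`, has not yet been measured in this assay. Its change from compound 1 is 3-chlorophenyl in place of 4-cyanophenyl on an aromatic nitrogen. Among the measured compounds shown here, of the measured steps, only the one from compound 1 to compound 3 bears on it, as that step also exchanges the nitrile for a halogen and gave a 1.6-fold higher number from compound 1 to compound 3 (0.22 log units; within the scatter); no measured compound carries a group placed as the 3-chlorophenyl is. A step of similar or slightly larger size toward a higher number is therefore expected, and compound 4 is estimated to give 230 nM, with a range from 110 nM to 480 nM, which would mean a 1.6-fold higher number from compound 1 to compound 4 (0.22 log units; within the scatter).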

Compound 4, half-maximal inhibitory concentration: 60 nM
The estimate for compound 4 lay 3.8-fold (0.58 log units) above the measured number; measured number below the stated range.
By their numbers in this assay, from the lowest: compounds 4, 2, 1 and 3 (each within the scatter of the next, the first and the last beyond it).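

In this assay, the group on the aromatic nitrogen proves able to take a chlorine-bearing ring: 3-chlorophenyl in place of 4-cyanophenyl gives a 2.3-fold lower number from compound 1 to compound 4 (0.37 log units; beyond the scatter), and in place of 4-fluorophenyl it gives a 3.8-fold lower number from compound 3 to compound 4 (0.58 log units; beyond the scatter). Compound 3 alone had suggested that a halogen in place of the nitrile raises the number, but compound 4 goes against this, while its comparison with the 2-cyanophenyl compound, a 1.7-fold lower number from compound 2 to compound 4 (0.22 log units; within the scatter), separates neither group from the other. Nothing measured here accounts for these steps.

The compounds shown leave open whether these steps belong to the chlorine itself or to where it sits on the phenyl ring. They also leave open how a phenyl ring carrying an amine or a carboxylic acid would read.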